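Replacing the hydroxy group in the long-chain series

The compounds below may be only part of what the source reports. "The series", "measured", "known", "first", "only" and "open" are said of these compounds alone.

Compound 1 (`CCC(CCO)n1cnc2c(Cl)ncnc21`) reads > 50000 nM in a functional assay on SW480 cells (Homo sapiens) for antiproliferative activity, read by MTT assay, with a stated time of 48 h (on this read-out lower numbers stand for stronger inhibition and higher numbers for weaker inhibition), and this is a limit of the assay, not a number. Compound 2 (`CCCCCCC(CCO)n1cnc2c(Cl)ncnc21`) gives 16700 nM on this read-out. Within the data shown here, compound 3 (`CCCCCCCCCC(CCO)n1cnc2c(Cl)ncnc21`) gives 1150 nM as the lowest number so far.

Each measured step extends the saturated chain: butyl gives a modest drop (an at least 2.9-fold lower number from compound 1 to compound 2 (0.47 log units; beyond the scatter)), a further propyl gives a large one (a 15-fold lower number from compound 2 to compound 3 (1.16 log units; beyond the scatter)), and heptyl gives a large one overall (an at least 43-fold lower number from compound 1 to compound 3 (1.63 log units; beyond the scatter)).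

Compound 4 (`CCCCCCCCCC(CCn1cc(-c2ccccc2)nn1)n1cnc2c(Cl)ncnc21`) keeps the chain of compound 3 and carries 4-phenyl-1H-1,2,3-triazol-1-yl in place of hydroxy on a saturated chain carbon, three bonds along the chain from an aromatic nitrogen. Among the measured compounds shown here, no measured step touches the hydroxy, so these steps set no direct size for this change, and the uncertainty is wide.

A modest move to a higher number is expected in this assay with an estimated size (a 2.6-fold higher number from compound 3 to compound 4 (0.42 log units; beyond the scatter)) that could prove larger. Compound 4 is estimated at 3000 nM with an expected range of 600 nM to 20000 nM on this read-out.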

Compound 4, half-maximal inhibitory concentration: 9920 nM
For compound 4 the middle estimate is 3.3-fold (0.52 log units) below the measured one, and the stated range covers the measured number.
By their numbers in this assay, from the lowest: compound 3; then compounds 4 and 2 (each within the scatter of the next). At a limit, above all of these: compound 1.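

The only step shown that touches the hydroxy, on a saturated chain carbon, three bonds along the chain from an aromatic nitrogen, gives in this assay an 8.6-fold higher number from compound 3 to compound 4 (0.94 log units; beyond the scatter), so this position responds to replacement in a way the chain steps could not size. With the chain of compound 3 kept, compound 4 still reads a number rather than a limit, 9920 nM, so a measurable read-out here does not depend on the hydroxy. Nothing measured here accounts for the size of this step.

Going by these compounds, the change removes a hydrogen-bond donor and adds two aromatic rings at once, so it remains open which of these sets the step, and how an amine, a methoxy group or a carboxylic acid would read at this position. Also open, on these data alone, is whether the chain trend of compounds 1 to 3 holds with 4-phenyl-1H-1,2,3-triazol-1-yl in place, or extends to a longer chain.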